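The source may hold more compounds than are shown below. What is called first, only, known or untested is meant among the compounds shown, and "the series" means these compounds.

Working notes on the endoperoxide series. In a functional assay on MCF7 cells (Homo sapiens) for inhibition (on this read-out lower numbers stand for stronger inhibition of growth and higher numbers for weaker inhibition of growth), compound 2, `C=C1CCC[C@H]2[C@](C)(CC[C@]3(C)CC[C@@H]([C@@H](C)C(=O)O)OO3)[C@@H](C)CC[C@]12C`, gives 3790 nM, the lowest of the two numbers recorded. Compound 1, `C=C1CCCC(C)(C)C1CC[C@]1(C)CC[C@H]([C@@H](C)C(=O)OC)OO1`, gives 18400 nM in this assay, a value separated from that of compound 2 by more than the usual scatter. Compound 3, `C=C1CCCC(C)(C)C1CC[C@@]1(C)CC[C@H]([C@@H](C)C(=O)O)OO1`, is reported in this assay only as > 12500 nM, which is a limit of the assay rather than a number. That entry is the limit of > 12500 nM in this assay, at which 1 of the 3 values shown sits.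

Compound 4, `C=C1CCC[C@H]2[C@](C)(CC[C@]3(C)CC[C@H]([C@@H](C)C(=O)O)OO3)[C@@H](C)CC[C@]12C`, has not yet been measured. Its relation to compound 2 is the two compounds have the same atoms and bonds and differ only in configuration as drawn: 1 of 7 stereo elements differ; a stereocentre at a saturated ring carbon is drawn S in compound 2 and R in compound 4. Among the compounds with values here, no measured pair in this set differs in a single place, so the size of such a step has no precedent here. Inversion of a single ring stereocentre may move the value in either direction; on balance a modest weakening in this assay is expected, possibly reaching beyond the scatter. The expected step is a 1.7-fold higher number from compound 2 to compound 4 (0.23 log units; within the scatter). Compound 4 is therefore estimated to give 6500 nM in this assay, within a range from 2000 nM to 20000 nM.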

Compound 4, concentration for 50% growth inhibition: 1780 nM
Estimate against measurement, compound 4: 3.7-fold (0.56 log units) above; the measured number lies below the stated range.
By their numbers in this assay, from the lowest: compound 4; then compound 2; then compound 1.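

In this assay, within the data shown here, inverting the stereocentre at a saturated ring carbon, drawn S in compound 2 and R in compound 4, gives a 2.1-fold lower number from compound 2 to compound 4 (0.33 log units; beyond the scatter), the first step that can be read at a single place. The step is modest, but it shows that this ring carbon is sensitive to configuration and that, of the two drawings, R gives the stronger inhibition of growth. The shift can be assigned to this one stereocentre because nothing else separates the pair: the fact that compounds 2 and 4 differ only in the configuration as drawn.

Going by these compounds, it remains open whether the same inversion would move the number in the same direction with a methyl ester or an amide in place of the carboxylic acid. Compound 3 is held only as a limit of the assay, so no step can be read from it: the limit of > 12500 nM in this assay, at which 1 of the 4 values shown sits.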